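The compounds below may be only part of what the source reports. "The series", "measured", "known", "first", "only" and "open" are said of these compounds alone.

Compound 1 `O=C(COc1ccc2oc(-c3ccccc3)cc(=O)c2c1)Nc1ccc(F)cc1` and compound 2 `COc1ccc(NC(=O)COc2ccc3oc(-c4ccccc4)cc(=O)c3c2)cc1` share one core and differ only at the far end of the amide. In a functional assay on NCI-H661 cells (Homo sapiens) for antiproliferative activity, read by MTT assay, with a stated time of 72 h (a higher number here means a weaker inhibitor of growth, a lower number a stronger inhibitor of growth), compound 1 gives 1470 nM, and compound 2 gives 840 nM. The change between them, (methoxy in place of fluoro on an aromatic carbon), produced a 1.8-fold lower number from compound 1 to compound 2 (0.24 log units; within the scatter).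

Compound 3 `O=C(COc1ccc2c(=O)c(-c3ccccc3)coc2c1)Nc1ccc(F)cc1` is built from the same atoms as compound 1, joined differently; how the two cores differ is not broken down here. In this assay compound 3 gives only a limit, > 10000 nM, and that is the limit of > 10000 nM in this assay, at which 1 of the 3 values shown sits.

Compound 4 `COc1ccc(NC(=O)COc2ccc3c(=O)c(-c4ccccc4)coc3c2)cc1` stands to compound 3 as compound 2 stands to compound 1: the change is methoxy in place of fluoro on an aromatic carbon, the same change, at the same place, as the earlier one. Because the earlier step was a 1.8-fold lower number from compound 1 to compound 2 (0.24 log units; within the scatter), a step of similar size is expected here. Compound 4 is therefore estimated at 9000 nM in this assay, with a range of 3000 nM to 30000 nM, which means an expected step of an at least 1.1-fold lower number from compound 3 to compound 4 (0.04 log units; that floor lies within the scatter), and a fair chance that only a limit is reported again.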

Compound 4, concentration for 50% growth inhibition: 9530 nM
The estimate for compound 4 lay 1.1-fold (0.02 log units) below the measured number, and the stated range covers the measured number.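

In this assay, methoxy in place of fluoro on the second core gave an at least 1.0-fold lower number from compound 3 to compound 4 (0.02 log units; that floor lies within the scatter). Set beside the step on the first core, the change can be compared only loosely: the same change on two cores in this assay, a 1.8-fold lower number (0.24 log units; within the scatter) from compound 1 to compound 2 and an at least 1.0-fold lower number (0.02 log units; that floor lies within the scatter) from compound 3 to compound 4; the limit leaves it open whether they differ. This shows that nothing printed for either core places the step from 4-fluorophenyl to 4-methoxyphenyl beyond the scatter, but it does not show that the change carries over from one core to the other with the same size, since compound 3 stands at a limit and not at a number: the limit of > 10000 nM in this assay, at which 1 of the 4 values shown sits.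

The compounds shown leave open whether an amine or a carboxylic acid in place of fluoro or methoxy, on an aromatic carbon of the same ring, would move the number on either core. They also leave open what a longer chain in place of methoxy would do, and whether any such group would behave alike on the two cores.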